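The source may hold more compounds than are shown below. What is called first, only, known or untested is meant among the compounds shown, and "the series" means these compounds.

Measured so far:
- compound 1, `CN1C(=O)COc2cc(Nc3cc4c(cn3)ncn4CC3CC3)cnc21`, > 1.66 h 
- compound 2, `Cc1nc(Nc2cnc3c(c2)OCC(=O)N3C)cc2c1ncn2CC1CC1`, > 1.66 h 
- compound 3, `CN1C(=O)COc2cc(Nc3ncc4ncn(CC5CC5)c4n3)cnc21`, 0.917 h 

Three compounds have been run in an ADME assay on microsomes from liver (Homo sapiens) for metabolic stability; a lower number here means that the compound disappears faster, a higher number that the compound lasts longer. For compound 1 the value > 1.66 h is a limit of the assay, not a number. For compound 2 the value > 1.66 h is likewise a limit. Compound 3 is the only one of the three that gives a number, 0.917 h.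

Compound 1 and compound 2 differ in one place: methyl in place of hydrogen on an aromatic carbon. The step that the two limits leave unreadable from compound 1 to compound 2 cannot be read in size because both compounds sit at the limit of > 1.66 h in this assay, at which 2 of the 3 values shown sit. So this pair shows only that both last beyond what this assay can follow.

Compound 4, `Cc1nc(Nc2cnc3c(c2)OCC(=O)N3C)nc2c1ncn2CC1CC1`, has not yet been measured. It comes from compound 3 by the same kind of change: methyl in place of hydrogen on an aromatic carbon. The surroundings of the place are not identical, since the ring of compound 3 holds two nitrogen atoms rather than one and the change sits opposite the ring nitrogen, so the two changes are alike in kind rather than the same. The difference between the core of compound 1 and the core of compound 3 is not broken down here.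

With the earlier step unreadable, the expectation for compound 4 rests mainly on the value of compound 3 in this assay, 0.917 h. The step of a 1.1-fold higher number from compound 3 to compound 4 (0.04 log units; within the scatter) is expected to stay small. Compound 4 is therefore estimated at 1 h in this assay, with a range from 0.5 h to 1.66 h.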

Compound 4, half-life: > 1.66 h
Compound 4 ended at the assay's limit; the forecaster's own chance of this, stated with the estimate: 30%; middle value at least 1.6-fold (0.22 log units) from the limit.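

In this assay, putting methyl in place of hydrogen on an aromatic carbon of the core of compound 3 gives an at least 1.8-fold higher number from compound 3 to compound 4 (0.25 log units; that floor lies within the scatter). On these data alone, compound 4 gives > 1.66 h, which is a limit of the assay and not a number, so only a floor for the step can be stated; that floor alone does not establish a real gain, and the true size of the step remains unknown. The same kind of change on the core of compound 1 cannot be read at all, so the series holds one step with only a floor and one with no readable size, and it cannot show whether the methyl acts to the same extent on both cores: the limit of > 1.66 h in this assay, at which 3 of the 4 values shown sit.

The compounds shown leave open how long compound 1, compound 2 and compound 4 truly last, and so how their stability compares. They also leave open whether the gain, if real, belongs to methyl alone or would also appear with another group at this place, such as ethyl, methoxy or an amine.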